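The source may report more compounds than this note shows. Statements on the series, on what has been measured and on what is new or still open speak of the compounds shown alone.

Measured so far in a functional assay on the whole organism for inhibition, with Mus musculus as the target, in the writhing test, with a stated time of 1 h; on this read-out higher numbers stand for an effect only at larger amounts of compound and lower numbers for an effect already at smaller amounts:
compound 1 `NC(=O)OC(CCN1CCN(c2cccc(Cl)c2)CC1)c1ccccc1` gives 0.57 mg/kg
compound 2 `NC(=O)OC(CCN1CCN(c2ccc(F)cc2)CC1)c1ccccc1` gives 0.55 mg/kg

Compound 2 stands at the lowest of the two numbers, but its nearest neighbour is compound 1, and the step of a 1.0-fold lower number from compound 1 to compound 2 (0.02 log units; within the scatter) lies within the scatter, so the two are not distinguished. Going by the values given here, that step, 4-fluorophenyl in place of 3-chlorophenyl on the amine nitrogen in the ring, is the only change on the aryl group seen so far.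

Compound 3 `Cc1ccccc1N1CCN(CCC(OC(N)=O)c2ccccc2)CC1` is not yet measured. It differs from compound 2 as follows: 2-methylphenyl in place of 4-fluorophenyl on an amine nitrogen in a ring. Among the compounds with values here, the one measured step that bears on it, the exchange of the aryl group on the same ring nitrogen, moved nothing beyond the scatter. For compound 3 no step beyond the scatter is therefore expected in this assay, with the expected step of a 1.1-fold higher number from compound 2 to compound 3 (0.04 log units; within the scatter). The estimate for compound 3 is 0.6 mg/kg, within 0.25 mg/kg to 1.5 mg/kg.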

Compound 3, dose for half-maximal effect: 1.96 mg/kg
Beside the measured number, compound 3's estimate is 3.3-fold (0.51 log units) below it; the measured number lies above the stated range.
By their numbers in this assay, from the lowest: compounds 2 and 1 (each within the scatter of the next); then compound 3.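

In this assay, the aryl group on the amine nitrogen in the ring is not indifferent to exchange: 2-methylphenyl gives a 3.6-fold higher number from compound 2 to compound 3 (0.55 log units; beyond the scatter) and a 3.4-fold higher number from compound 1 to compound 3 (0.54 log units; beyond the scatter). The earlier pair, 3-chlorophenyl and 4-fluorophenyl, could not be told apart, so only now does this position show a response, with an effect needing a larger amount of compound 3. Both steps are modest, and no measured evidence bears on the reason for them.

The compounds shown leave open whether the shift goes with the methyl group itself or with its place on the phenyl ring, a question that 4-methylphenyl and 2-chlorophenyl on the same nitrogen would address. As far as these compounds go, how a 2-pyridyl group at this nitrogen would compare also remains open.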